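The compounds below may be only part of what the source reports. "The series", "measured", "known", "first", "only" and "open" are said of these compounds alone.

Compound 1 `O=C(NCCCNc1nc(Nc2ccccc2F)ncc1C1CC1)c1cccs1`: 820 nM
Compound 2 `CN(C)Cc1ccc(Nc2ncc(C3CC3)c(NCCCNC(=O)C3CCC3)n2)cc1`: 6 nM
Compound 3 `Cn1ccc(Nc2ncc(C3CC3)c(NCCCNC(=O)C3CCC3)n2)n1`: a limit of the assay, > 1000 nM

In an assay on isolated protein for inhibition of serine/threonine-protein kinase TBK1 (Homo sapiens) (a higher number here means a weaker inhibitor, a lower number a stronger inhibitor), compound 1 gives 820 nM, the higher of the two numbers available; compound 2 gives 6 nM, far lower. Compound 3 reaches only a limit, > 1000 nM (the limit of > 1000 nM in this assay, at which 1 of the 3 values shown sits). Compound 4 `O=C(NCCCNc1nc(Nc2cccc(F)c2)ncc1C1CC1)c1cccs1` differs from compound 1 in one place: 3-fluorophenyl in place of 2-fluorophenyl on a nitrogen on an aromatic ring. Within the data shown here, the single measured step, an at least 160-fold higher number from compound 2 to compound 3 (2.22 log units; beyond the scatter), swaps the entire group on that nitrogen rather than shifting a fluorine within a phenyl ring, so it does not bear directly on this change. Among the measured compounds shown here, with no step that speaks to the fluorine position, compound 4 is expected to stay close to compound 1, a step within the scatter, a 1.0-fold lower number from compound 1 to compound 4 (0.01 log units; within the scatter). The estimate for compound 4 is 800 nM, in the range 250 nM to 2500 nM.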

Compound 4, half-maximal inhibitory concentration: 110 nM
Estimate against measurement, compound 4: 7.3-fold (0.86 log units) above; measured number outside the range, below it.
By their numbers in this assay, from the lowest: compound 2; then compound 4; then compound 1. At a limit, above all of these: compound 3.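

Moving the fluorine alone, with the same atoms joined differently, gives a 7.5-fold lower number from compound 1 to compound 4 (0.87 log units; beyond the scatter). So the group on this nitrogen responds to where a single fluorine sits on the phenyl ring, whereas the earlier compounds showed only the effect of replacing the whole group. Nothing measured here gives a reason for this change. Still open, going by these compounds, is how a plain phenyl group, or a chlorine or a nitrile in place of the fluorine, would read on the core of compound 1.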